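Bromo for Fluoro on the Aryl Arm of a Shared Core

The compounds below may be only part of what the source reports. "The series", "measured", "known", "first", "only" and "open" are said of these compounds alone.

In a functional assay on MCF7 cells (Homo sapiens) for antiproliferative activity, read by MTT assay, with a stated time of 24 h, tested at 25 uM (a lower number here means a stronger effect, a higher number a weaker effect of the compound at the concentration tested), compound 1 `OC(CCn1nc2c(Br)c(Br)c(Br)c(Br)c2n1)c1ccc(F)cc1` gives 101%. Compound 2 `C[C@@H](O)CCn1nc2c(Br)c(Br)c(Br)c(Br)c2n1` gives 105%, and compound 3 `C[C@H](O)CCn1nc2c(Br)c(Br)c(Br)c(Br)c2n1` gives 102%. Compound 1 holds the lowest of the three numbers, yet its gaps to compound 3 and to compound 2 both lie within the scatter, so the three compounds cannot be told apart in this assay and none of them shows a clear effect at the concentration tested. Among the measured compounds shown here, the one measured step between neighbouring compounds, a number 3 percentage points lower from compound 2 to compound 3 (within the scatter), stays within the scatter; the two compounds involved share the same atoms and bonds, and the fact that compounds 2 and 3 differ only in the configuration as drawn is all that separates them.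

Compound 4 `OC(CCn1nc2c(Br)c(Br)c(Br)c(Br)c2n1)c1ccc(Br)cc1` differs from compound 1 by bromo in place of fluoro on an aromatic carbon. For the measured compounds named here, no measured step touches this exchange: the only step on record concerns configuration at a saturated chain carbon, not a halogen on the aromatic ring, and it bears on the present change only in showing that a small alteration left the read-out in this assay unmoved. The account therefore expects for compound 4 a step of a number 1 percentage points lower from compound 1 to compound 4 (within the scatter), no movement beyond the scatter in either direction. For compound 4 the estimated value in this assay is 100%, with a range from 88% to 112%.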

Compound 4, a percentage reported as activity, at one concentration (the size of the read-out at that concentration, not a potency): 59%
Beside the measured number, compound 4's estimate is 41 percentage points above it; the measured number lies below the stated range.
By their numbers in this assay, from the lowest: compound 4; then compounds 1, 3 and 2 (each within the scatter of the next).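

In this assay the halogen on the aryl arm proves able to move the read-out: bromo in place of fluoro gives a number 42 percentage points lower from compound 1 to compound 4 (beyond the scatter) and so turns a compound with no clear effect at the concentration tested into one with a clear effect. Among the compounds shown here, the position on an aromatic carbon, para to a large group, is therefore sensitive to the exchange of 4-fluorophenyl for 4-bromophenyl, something the earlier compounds could not show, as their only measured step, a number 3 percentage points lower from compound 2 to compound 3 (within the scatter), concerned configuration at a saturated chain carbon. The exchange alters neither the count of hydrogen-bond donors and acceptors nor the net charge, so the step arises without a change in any of these counts.

The compounds shown leave open whether chloro, iodo, a methyl group, an amine or a carboxylic acid at the same place would lower the number as bromo does, and whether the hydroxyl-bearing chain of compound 4 has any part in the step. The one fact on record concerns only configuration and does not bear on this exchange, so what lies behind the step stays unexplained.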